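This account rests on a few compounds, and the source may have more. Where it says the series, first, only, none or still open, it means among the compounds named here.

Compound 1 `CC(C)(C#Cc1ccc(NC(=O)CSc2nnnn2-c2ccc(C3CC3)cc2Cl)c(Cl)c1)OCC(=O)O`: 0.483 h
Compound 2 `CC(C)(C#Cc1ccc(NC(=O)CSc2nnnn2-c2ccc(C3CC3)cc2Cl)c(Cl)c1)NC(=O)CN`: 1.82 h

Of the two compounds measured in an in vitro ADME assay on microsomes from liver (Rattus norvegicus) for metabolic stability, tested at 2 uM (on this read-out lower numbers stand for a shorter-lived compound and higher numbers for a longer-lived compound), compound 1 gives the lower number, 0.483 h, while compound 2 gives 1.82 h. For the measured compounds named here, the only measured step, a 3.8-fold higher number from compound 1 to compound 2 (0.58 log units; beyond the scatter), exchanges the carboxymethoxy group for ((aminomethyl)carbonyl)amino on a saturated chain carbon bound to two saturated chain carbons and a triple-bonded carbon.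

Compound 3 `CC(C)(C#Cc1ccc(NC(=O)CSc2nnnn2-c2ccc(C3CC3)cc2Cl)c(Cl)c1)C(=O)NS(C)(=O)=O` changes the same position of compound 1 in a different way: (methylsulfonyl)carbamoyl in place of carboxymethoxy on a saturated chain carbon bound to two saturated chain carbons and a triple-bonded carbon. The step from compound 1 to compound 2 is the only one that bears on this, and it was modest. With a different entering group, the size of the step to compound 3 in this assay is uncertain; a small rise is expected, a 1.7-fold higher number from compound 1 to compound 3 (0.22 log units; within the scatter), though it may stay within the scatter. Compound 3 is therefore estimated at 0.8 h in this assay, within the range 0.35 h to 1.8 h.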

Compound 3, half-life: 1.37 h
Estimate against measurement, compound 3: 1.7-fold (0.23 log units) below; measured number inside the range.
By their numbers in this assay, from the lowest: compound 1; then compounds 3 and 2 (each within the scatter of the next).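

In this assay a second entering group on the same saturated chain carbon also gives a 2.8-fold higher number from compound 1 to compound 3 (0.45 log units; beyond the scatter) and so the rise is not confined to ((aminomethyl)carbonyl)amino. The two entering groups are not separated, with a 1.3-fold lower number from compound 2 to compound 3 (0.12 log units; within the scatter) between them, so of the three compounds only compound 1, which carries carboxymethoxy, stands apart. Nothing in the available data explains why the number changes with this replacement.

The compounds shown leave open whether a carboxylic acid bound directly to that saturated chain carbon, or a primary amine there, would fall with compound 1 or with compounds 2 and 3. They also leave open whether a longer chain in place of carboxymethoxy would give a number different from those of the three compounds.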